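Compound 1 and a fluoropyrimidine swap in a cytotoxicity assay

The source may report more compounds than this note shows. Statements on the series, on what has been measured and on what is new or still open speak of the compounds shown alone.

compound 1 `O=C1CC(c2cnc(C(F)(F)F)s2)CN1c1cnn2c1CN(C(=O)Nc1cc(F)c(F)c(F)c1)C(C1CC1)C2` gives 38500 nM
compound 2 `CC1CCn2ncc(N3CC(c4ccccc4)CC3=O)c2CN1C(=O)Nc1cc(F)c(F)c(F)c1` gives > 2000 nM

Going by the values given here, in a toxicity assay on HepG2 2.2.15 cells (Homo sapiens) for cytotoxicity, read by CellTiter-Glo (a higher number here means that more compound is tolerated, a lower number that less compound is tolerated), compound 1 holds the only true number (38500 nM). For compound 2 the entry (> 2000 nM) is a limit of the assay, not a number. Compound 3 `O=C1CC(c2ncc(F)cn2)CN1c1cnn2c1CN(C(=O)Nc1cc(F)c(F)c(F)c1)C(C1CC1)C2` differs from compound 1 by one change (5-fluoropyrimidin-2-yl in place of 2-(trifluoromethyl)-1,3-thiazol-5-yl on a saturated ring carbon), with 5-fluoropyrimidin-2-yl in place of 2-(trifluoromethyl)-1,3-thiazol-5-yl on a saturated ring carbon. Among the compounds with values here, no measured pair shows a comparable swap, so no step beyond the scatter is expected in this assay, and no direction is favoured. The estimated change is small (a 1.0-fold higher number from compound 1 to compound 3 (0.02 log units; within the scatter)). Compound 3 is expected at 40000 nM, within an estimated range of 15000 nM to 100000 nM.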

Compound 3, half-maximal cytotoxic concentration: 115000 nM
For compound 3 the middle estimate is 2.9-fold (0.46 log units) below the measured one; the whole stated range lies below it.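

In this assay, the group on this saturated ring carbon proves able to shift the tolerated concentration: replacing 2-(trifluoromethyl)-1,3-thiazol-5-yl with 5-fluoropyrimidin-2-yl gives a 3.0-fold higher number from compound 1 to compound 3 (0.48 log units; beyond the scatter). This is the only pair shown that differs in one place, so the position's influence could not be read before. The step does not tell which feature of the two groups carries it.

As far as these compounds go, whether a morpholine or a carboxylic acid at this carbon would move the number in the same direction stays open. Compound 2 holds only a limit, not a number, and differs in more than one place: the limit of > 2000 nM in this assay, at which 1 of the 3 values shown sits.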